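Replacing a carboxymethyl group with a carbamate-like methoxycarbonyl

This account rests on a few compounds, and the source may have more. Where it says the series, first, only, none or still open, it means among the compounds named here.

Compound 1 `Cc1cn([C@@H]2O[C@H](CO[Si](C)(C)C(C)(C)C)[C@@]3(OS(=O)(=O)C=C3NCC(=O)O)[C@H]2O[Si](C)(C)C(C)(C)C)c(=O)n(C)c1=O` is a nucleoside derivative carrying two bulky silyl protecting groups and a cyclic sulfonate fused to the sugar, with a carboxymethyl chain on an amine nitrogen. In a functional assay on CCRF-CEM cells (Homo sapiens) (on this read-out higher numbers stand for lower toxicity in this test and lower numbers for higher toxicity in this test), compound 1 gives 65000 nM, a weak effect. Within the data shown here, its only measured neighbour is compound 2 `COC(=O)CNC1=CS(=O)(=O)O[C@@]12[C@@H](CO[Si](C)(C)C(C)(C)C)O[C@@H](n1cc(C)c(=O)n(C)c1=O)[C@@H]2O[Si](C)(C)C(C)(C)C`, the methyl ester of that acid, which in this assay gives 96000 nM. The step of a 1.5-fold higher number from compound 1 to compound 2 (0.17 log units; within the scatter) is within the scatter, so the two cannot be told apart on these numbers; both sit in the same weakly toxic region.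

Compound 3 `COC(=O)NC1=CS(=O)(=O)O[C@@]12[C@@H](CO[Si](C)(C)C(C)(C)C)O[C@@H](n1cc(C)c(=O)n(C)c1=O)[C@@H]2O[Si](C)(C)C(C)(C)C` has not been measured. It differs from compound 1 by methoxycarbonyl in place of carboxymethyl on an amine nitrogen. Among the measured compounds shown here, this is a rearrangement of the same atoms rather than an addition, and no measured step tests exactly this change. For the measured compounds named here, the one step available, from an acid to its ester, shows that altering the group on this nitrogen left the read-out essentially unchanged. A step of about a 1.2-fold higher number from compound 1 to compound 3 (0.09 log units; within the scatter) is therefore expected, not beyond the scatter. For compound 3 a value of 80000 nM is estimated, with a plausible range from 30000 nM to 200000 nM.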

Compound 3, half-maximal cytotoxic concentration: 30700 nM
The estimate for compound 3 lay 2.6-fold (0.42 log units) above the measured number, and the stated range covers the measured number.
By their numbers in this assay, from the lowest: compound 3; then compounds 1 and 2 (each within the scatter of the next).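

The group on this amine nitrogen does affect the read-out in this assay, a point that the earlier pair could not show: the acid and its methyl ester stayed within the scatter of each other (a 1.5-fold higher number from compound 1 to compound 2 (0.17 log units; within the scatter)). Methoxycarbonyl, by contrast, gives a modest change beyond the scatter against carboxymethyl (a 2.1-fold lower number from compound 1 to compound 3 (0.33 log units; beyond the scatter)) and against (methoxycarbonyl)methyl (a 3.1-fold lower number from compound 2 to compound 3 (0.50 log units; beyond the scatter)), which makes compound 3 the most toxic of the three in this test, although the same atoms are present in compounds 1 and 3 and all three numbers remain high. No measurement here bears on what lies behind this difference.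

Going by these compounds, it remains open whether the lower number is specific to methoxycarbonyl or would also appear with an acetyl group or the longer ethoxycarbonyl chain on the same nitrogen. The result also leaves open what a plain amine, with only hydrogen in place of these groups, would give on the shared core.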